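Compound 4: bromine-bearing group on the shared core

The compounds below may be only part of what the source reports. "The series", "measured", "known", "first", "only" and "open" are said of these compounds alone.

Measured in a functional assay on HeLa cells (Homo sapiens) for antiproliferative activity, read by MTT assay, with a stated time of 72 h; on this read-out higher numbers stand for weaker inhibition and lower numbers for stronger inhibition
compound 1 `O=C1O/C(=C\Cn2cnc3c(F)nc(F)c(Cl)c32)C(OCc2ccccc2)=C1OCc1ccccc1` gives > 100000 nM
compound 2 `O=C1NC(O)(CCn2cnc3cc[nH]c3c2=O)C(OCc2ccccc2)=C1OCc1ccccc1` gives 92000 nM
compound 3 `O=C1O/C(=C\Cn2cnc3cc[nH]c3c2=O)C(OCc2ccccc2)=C1OCc1ccccc1` gives 27000 nM

The entry for compound 1 is a limit of the assay, not a number. Compound 3 holds the lowest number in this assay, and compound 2 is the nearest number above it.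

Compound 4 `O=C1O/C(=C\Cn2cnc3cncc(Br)c32)C(OCc2ccccc2)=C1OCc1ccccc1` differs from compound 3 as follows: a group of 10 heavy atoms (6 carbon, 3 nitrogen, 1 bromine; one five-membered aromatic ring with 2 hetero atoms, one six-membered aromatic ring with 1 hetero atom) in place of a group of 10 heavy atoms (6 carbon, 3 nitrogen, 1 oxygen; one five-membered aromatic ring with 1 hetero atom, one six-membered aromatic ring with 2 hetero atoms), on a saturated chain carbon bound to a double-bonded chain carbon. For the measured compounds named here, the one measured step that bears on this is an at least 3.7-fold lower number from compound 1 to compound 3 (0.56 log units; beyond the scatter), and its size rests on (the limit of > 100000 nM in this assay, at which 1 of the 3 values shown sits). The entering group has the same aromatic ring counts as the group that compound 3 replaces in that step, so a modest move back toward weaker inhibition is expected. The expected change is a 2.0-fold higher number from compound 3 to compound 4 (0.31 log units; beyond the scatter). Compound 4 is estimated at 55000 nM, within an expected range of 20000 nM to 100000 nM.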

Compound 4, half-maximal inhibitory concentration: 15000 nM
Compound 4: the middle estimate sits 3.7-fold (0.56 log units) above what was measured; the whole stated range lies above it.
By their numbers in this assay, from the lowest: compounds 4 and 3 (each within the scatter of the next); then compound 2. At a limit, above all of these: compound 1.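

At this place, on a saturated chain carbon bound to a double-bonded chain carbon, the exchange of groups gives no difference that can be read in this assay: a 1.8-fold lower number from compound 3 to compound 4 (0.26 log units; within the scatter). The entering group has 0 hydrogen-bond donors, so the donor of the leaving group is not needed to hold this level. The step against the group with two fluorine atoms and one chlorine is an at least 6.6-fold lower number from compound 1 to compound 4 (0.82 log units; beyond the scatter), but compound 1 is a limit, so its size is only a bound: the limit of > 100000 nM in this assay, at which 1 of the 4 values shown sits.

As far as these compounds go, whether an amine or a carboxylic acid in place of the bromine would hold this level remains open. So does the effect of a longer chain at this place.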